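Thiophen-2-yl in Place of Furan-2-yl: Compound 3 Expected

A few compounds are considered here, and "the series" means these few. Any claim that something is new, unique, unknown or untested is made for them only; others in the source may bear on it.

Of the compounds shown here, two have been measured in a functional assay on MCF7 cells (Homo sapiens) for cytotoxicity, read by MTT assay, with a stated time of 48 h; on this read-out higher numbers stand for weaker inhibition and lower numbers for stronger inhibition. Compound 1 `CCCCCCCCNC(=O)[C@@H](NC(=O)c1cccs1)[C@@H](C)O` gives 72500 nM. Compound 2 `CCCCCCCCCCCCCCNC(=O)[C@@H](NC(=O)c1ccco1)[C@@H](C)O` gives 105000 nM, which stands at the top of these two numbers, although its distance from compound 1 lies within the scatter. Compound 3 `CCCCCCCCCCCCCCNC(=O)[C@@H](NC(=O)c1cccs1)[C@@H](C)O` differs from compound 2 by thiophen-2-yl in place of furan-2-yl on a carbonyl carbon. Within the data shown here, no measured pair isolates this exchange, so any step in this assay is expected to remain within the scatter, leaning at most slightly toward a lower number. The expected step is a 1.2-fold lower number from compound 2 to compound 3 (0.09 log units; within the scatter). Compound 3 is therefore estimated at 85000 nM, within a range from 40000 nM to 180000 nM.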

Compound 3, half-maximal inhibitory concentration: 36100 nM
Beside the measured number, compound 3's estimate is 2.4-fold (0.37 log units) above it, and the stated range ends above it.
By their numbers in this assay, from the lowest: compounds 3, 1 and 2 (each within the scatter of the next, the first and the last beyond it).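

In this assay, thiophen-2-yl in place of furan-2-yl on a carbonyl carbon gives a 2.9-fold lower number from compound 2 to compound 3 (0.46 log units; beyond the scatter), so this exchange can now be read on its own and its step lies beyond the scatter. Hexyl in place of hydrogen on a saturated chain carbon, eight bonds along the chain from an amide-type nitrogen, gives a 2.0-fold lower number from compound 1 to compound 3 (0.30 log units; within the scatter), which stays within the scatter with thiophen-2-yl held in place. No evidence bears on the cause of either step.

The compounds shown leave open whether the exchange carries over to the shorter chain of compound 1. They also leave open how a phenyl on the carbonyl carbon, or a longer chain, would read.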